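This account rests on a few compounds, and the source may have more. Where it says the series, first, only, none or still open, it means among the compounds named here.

Measured so far in an assay on CHO cells for displacement of a labelled ligand from adenosine receptor A3 (Homo sapiens), read by scintillation counting, tested at 10 uM; a lower number here means less inhibition, a higher number more inhibition at the concentration tested (going by the name of the read-out):
compound 1 `Cc1c(Br)sc(N)c1C(=O)c1ccc(Cl)cc1`: 1%
compound 2 `CC(C)(C)Cc1c(-c2cccnc2)sc(N)c1C(=O)c1ccc(Cl)cc1`: 1%
compound 3 `Cc1ccc(C(=O)c2c(CC(C)(C)C)csc2N)cc1`: 1%

Compound 2 stands level with compound 1 and compound 3 at the digits shown; no pair among the three differs beyond the scatter. None of these compounds differ from one another in a single place, so no step between measured compounds is at hand.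

Compound 4 `CC(C)(C)Cc1c(-c2ccccc2)sc(N)c1C(=O)c1ccc(Cl)cc1` is yet to be measured in this assay. It differs from compound 2 by phenyl in place of pyridin-3-yl on an aromatic carbon.

With all three measured compounds at the same low reading, nothing here points to a step in either direction; no step beyond the scatter is expected. Compound 4 is expected to give 2%, within 0% to 12%. The expected step of a number 1 percentage points higher from compound 2 to compound 4 (within the scatter) is none beyond the scatter.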

Compound 4, a percentage reported as inhibition, at one concentration (the size of the read-out at that concentration, not a potency): 1%
Compound 4: the middle estimate sits 1 percentage points above what was measured, within the range that was stated.
By their numbers in this assay, from the lowest: compounds 1, 2, 3 and 4 (each within the scatter of the next).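

In this assay the first single-place comparison gives no change at the digits printed from compound 2 to compound 4 (within the scatter) for phenyl in place of pyridin-3-yl on the aromatic carbon next to the ring sulfur. At this position, then, exchanging the ring with one hetero atom for the carbon-only ring does not move the reading, and the hydrogen-bond acceptor that leaves makes no difference that can be read here. Both compounds read low, so this comparison shows no route to more inhibition.

Open, from the compounds shown here alone, is whether a carboxylic acid or an aminomethyl group on this ring would give a higher reading. Also open, going by these compounds, is whether a shorter chain in place of the neopentyl group would change anything with the phenyl kept. No measurement available offers an explanation for this result.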